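Swapping an ether side chain for isobutyl on a benzoxazolone core

This account rests on a few compounds, and the source may have more. Where it says the series, first, only, none or still open, it means among the compounds named here.

Measured compounds:
compound 1, `COCCOc1cc2oc(=O)n(CCC(=O)O)c2cc1Cl`: 31.6 nM
compound 2, `Cc1ccc([C@@H](C)Oc2cc3oc(=O)n(CCC(=O)O)c3cc2Cl)nc1`: 3.16 nM

In an assay for inhibition of kynurenine 3-monooxygenase (Homo sapiens), read by mass spectrometry, with a stated time of 1 h (a lower number here means a stronger inhibitor, a higher number a weaker inhibitor), compound 1 gives 31.6 nM, the higher of the two numbers recorded. Compound 2 gives 3.16 nM, a gap that lies beyond the usual scatter. Compound 3, `CC(C)Cc1cc2oc(=O)n(CCC(=O)O)c2cc1Cl`, is not yet measured. It differs from compound 1 by isobutyl in place of 2-methoxyethoxy on an aromatic carbon. Among the measured compounds shown here, no measured pair shows this kind of exchange, so the step from compound 1 to compound 3 is expected to stay within the scatter, with no clear direction: a 1.1-fold lower number from compound 1 to compound 3 (0.02 log units; within the scatter). For compound 3 the estimated value in this assay is 30 nM, within 8 nM to 120 nM.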

Compound 3, half-maximal inhibitory concentration: 12.6 nM
Compound 3: the middle estimate sits 2.4-fold (0.38 log units) above what was measured, and the stated range covers the measured number.
By their numbers in this assay, from the lowest: compound 2; then compound 3; then compound 1.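

In this assay, isobutyl in place of 2-methoxyethoxy on this aromatic carbon, ortho to a chloro group, gives a 2.5-fold lower number from compound 1 to compound 3 (0.40 log units; beyond the scatter) and so brings a modest gain. The side chain's two hydrogen-bond acceptors are therefore not needed at this position for the number to stay low, and an all-carbon group serves at least as well here. Nothing on hand explains the change. The compounds shown leave open how an amine or a carboxylic acid at this position would compare with isobutyl, and whether a longer all-carbon chain would lower the number further.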